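The source may report more compounds than this note shows. Statements on the series, on what has been measured and on what is new or still open speak of the compounds shown alone.

The account concerns a set of compounds sharing one core, illustrated by compound 1 `CCCCNc1nc(N)nc2c1CNCC2`, and tested in an assay on HEK293 cells for agonist activity at Toll-like receptor 8 (Homo sapiens), read by a luciferase reporter, with a stated time of 6 h; on this read-out lower numbers stand for an effect already at smaller amounts and higher numbers for an effect only at larger amounts of compound. Compound 1 gives 7.2 uM. Compound 2 `CCCCNc1nc(N)nc2c1CN(C(=O)C(C)C)CC2` carries an isopropylcarbonyl on the ring amine nitrogen, and in this assay compound 2 gives 1.6 uM, which corresponds to a 4.5-fold lower number from compound 1 to compound 2 (0.65 log units; beyond the scatter). Compound 3 `CCCCNc1nc(N)nc2c1CN(C(=O)c1cocn1)CC2` carries a (1,3-oxazol-4-yl)carbonyl at the same place, and in this assay compound 3 gives 0.2 uM. That corresponds to a 36-fold lower number from compound 1 to compound 3 (1.56 log units; beyond the scatter) and to an 8.0-fold lower number from compound 2 to compound 3 (0.90 log units; beyond the scatter). Among the three measured compounds, compound 3 therefore stands at the lowest number, with both other compounds beyond the scatter from it.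

Compound 4 `CCCCNc1nc(N)nc2c1CN(C(=O)c1cc(C)on1)CC2` is not yet measured. It differs from compound 3 in one place: 5-methyl-1,2-oxazol-3-yl in place of 1,3-oxazol-4-yl on a carbonyl carbon. Among the compounds with values here, no measured step exchanges one five-membered aromatic ring for another on the carbonyl carbon, so no step bears directly on this change. The steps that come nearest are those from compound 2 and compound 1 to compound 3, which show that a five-membered aromatic ring on the carbonyl carbon sits at a lower number than an isopropyl or a hydrogen. Since compound 4 keeps such a ring, one would expect a step of about a 1.5-fold higher number from compound 3 to compound 4 (0.18 log units; within the scatter) in this assay, that is, no step beyond the scatter. Compound 4 is accordingly estimated at 0.3 uM, within a range from 0.1 uM to 1 uM.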

Compound 4, minimum effective concentration: 0.4 uM
Beside the measured number, compound 4's estimate is 1.3-fold (0.12 log units) below it; the range from low to high includes it.
By their numbers in this assay, from the lowest: compounds 3 and 4 (each within the scatter of the next); then compound 2; then compound 1.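

In this assay the exchange of 1,3-oxazol-4-yl for 5-methyl-1,2-oxazol-3-yl on the carbonyl carbon gives a 2.0-fold higher number from compound 3 to compound 4 (0.30 log units; within the scatter) and so stays within the scatter, which shows that this position accepts a second five-membered aromatic ring with 2 hetero atoms, here one carrying a methyl, without a change that can be told apart from repeated measurement. The low number of compound 3 is therefore not tied to 1,3-oxazol-4-yl alone, as the new ring also gives a 4.0-fold lower number from compound 2 to compound 4 (0.60 log units; beyond the scatter) and an 18-fold lower number from compound 1 to compound 4 (1.26 log units; beyond the scatter) in this assay and both steps lie beyond the scatter, so that two such rings now stand apart from isopropyl on the carbonyl carbon and from hydrogen on the ring amine nitrogen. Nothing given here accounts for why the two rings read alike.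

From the compounds shown here alone, the step from compound 3 to compound 4 changes the arrangement of the ring atoms and adds the methyl together, so the share of each remains open. Also open, going by these compounds, is how a phenyl ring, a pyridine ring or a longer carbon chain on the carbonyl carbon would read in this assay on the shared core.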